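The source may report more compounds than this note shows. Statements on the series, on what has been measured and on what is new or still open speak of the compounds shown alone.

In a functional assay on CHO cells for agonist activity at adenosine receptor A1 (Homo sapiens), read by fluorescence and ERK phosphorylation, with stated times of 30 min and 1.5 h, tested at 10 uM (on this read-out lower numbers stand for a weaker effect and higher numbers for a stronger effect at the one concentration tested), the measured compounds read:

Compound 1 `Nc1scc(-c2ccc(F)cc2)c1C(=O)c1ccccc1`: 60%
Compound 2 `Nc1scc(-c2cccc(Cl)c2)c1C(=O)c1ccccc1`: 52%
Compound 3 `Nc1scc(-c2ccc(F)cc2)c1C(=O)c1ccc(Cl)cc1`: 61%

Compound 3 differs from compound 1 by chloro in place of hydrogen on an aromatic carbon, and the step is a number 1 percentage points higher from compound 1 to compound 3 (within the scatter). Compound 2 differs from compound 1 by 3-chlorophenyl in place of 4-fluorophenyl on an aromatic carbon, giving the step of a number 8 percentage points lower from compound 1 to compound 2 (within the scatter). Compound 4 `Nc1scc(-c2cccc(Cl)c2)c1C(=O)c1ccc(Cl)cc1` has not been measured; it differs from compound 3 by 3-chlorophenyl in place of 4-fluorophenyl on an aromatic carbon. This is the same kind of change as that from compound 1 to compound 2, but not the same: around the place, the ring atom next to it bears a group of 8 heavy atoms in compound 1 and a group of 9 heavy atoms in compound 3. Resting on the step of a number 8 percentage points lower from compound 1 to compound 2 (within the scatter) seen between compound 1 and compound 2, a step of a number 8 percentage points lower from compound 3 to compound 4 (within the scatter) is expected here. Compound 4 is estimated at 53%, likely between 40% and 66%.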

Compound 4, a percentage reported as activity, at one concentration (the size of the read-out at that concentration, not a potency): 75%
Beside the measured number, compound 4's estimate is 22 percentage points below it; the measured number lies above the stated range.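

In this assay, the swap to 3-chlorophenyl from 4-fluorophenyl gives a number 14 percentage points higher from compound 3 to compound 4 (beyond the scatter), so the earlier step does not carry over to the core with the added chloro: the same change on two cores in this assay, a number 8 percentage points lower (within the scatter) from compound 1 to compound 2 and a number 14 percentage points higher (beyond the scatter) from compound 3 to compound 4, 22 percentage points apart, beyond the scatter of two such steps. The chloro in place of hydrogen gives a number 23 percentage points higher from compound 2 to compound 4 (beyond the scatter), and it does not carry over either: the same change on two cores in this assay, a number 1 percentage points higher (within the scatter) from compound 1 to compound 3 and a number 23 percentage points higher (beyond the scatter) from compound 2 to compound 4, 22 percentage points apart, beyond the scatter of two such steps. The two changes therefore do not simply add up in these four compounds, where the effect of each depends on the other, but this does not show why, or whether the same holds for other groups.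

On these data alone, it remains open whether a methyl or methoxy group in place of the chloro would behave the same way. Each compound was read at one concentration, so these numbers tell only of a stronger or weaker effect at that concentration.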